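Two Indole-Derived Oxindoles and a Methoxy Variant

The source may report more compounds than this note shows. Statements on the series, on what has been measured and on what is new or still open speak of the compounds shown alone.

Measured compounds:
compound 1 `COc1c(/C=C2/C(=O)Nc3ccc(Cl)cc32)c2ccccc2n1-c1ccccc1` — 13800 nM
compound 2 `COc1cc2c(/C=C3/C(=O)Nc4ccc(O)cc43)c(Cl)n(Cc3cc(OC)c(OC)c(OC)c3)c2cc1C` — 34700 nM
compound 3 `O=C1/C(=C/c2c(Cl)[nH]c3ccccc23)c2ccccc2N1Cc1ccccc1` — 56200 nM

Of the compounds shown here, three have been tested in a functional assay on cells (Cancer cell lines, Homo sapiens) for cytotoxicity, with a stated time of 48 h; a higher number here means a weaker inhibitor of growth, a lower number a stronger inhibitor of growth. Compound 1 gives 13800 nM, compound 2 gives 34700 nM, and compound 3 gives 56200 nM. Among these three numbers compound 2 holds the second highest. Its nearest neighbour is compound 3, whose value lies within the usual scatter of compound 2, so the two cannot be told apart. Compound 1 lies furthest away, with a lower number than compound 2 by a gap that is beyond the scatter.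

Compound 4 `COc1ccc2c(c1)/C(=C\c1c(Cl)n(Cc3cc(OC)c(OC)c(OC)c3)c3cc(C)c(OC)cc13)C(=O)N2` has not yet been measured in this assay. It differs from compound 2 in one place: methyl in place of hydrogen on an oxygen on an aromatic ring. For the measured compounds named here, no step between two measured compounds shows how such a change moves the number, so the expectation rests on the size of the change alone, which is a single carbon added.

A small step is expected, possibly none beyond the scatter, with no clear direction; the expected step from compound 2 to compound 4 is a 1.2-fold lower number from compound 2 to compound 4 (0.06 log units; within the scatter). Compound 4 is therefore estimated at 30000 nM, within a range from 10000 nM to 90000 nM.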

Compound 4, concentration for total growth inhibition: 57500 nM
For compound 4 the middle estimate is 1.9-fold (0.28 log units) below the measured one; the range from low to high includes it.
By their numbers in this assay, from the lowest: compound 1; then compounds 2, 3 and 4 (each within the scatter of the next).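

In this assay, for the compounds shown here, the change from hydroxy to methoxy on this oxygen on an aromatic ring gives a 1.7-fold higher number from compound 2 to compound 4 (0.22 log units; within the scatter) and is the first direct reading of any single change in this set. Compounds 2 and 4 therefore cannot be told apart, so the data give no sign that the hydrogen on this oxygen matters for this read-out in this one pair. No supporting measurement bears on this result.

Going by these compounds, whether a longer chain on this oxygen, such as ethoxy or benzyloxy, would also leave the number within the scatter remains open, as does the effect of putting an amine or a carboxylic acid at this place. A single pair also cannot show whether the same change would behave alike on a different core.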